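From 4-chlorophenyl to 3-chlorophenyl: expecting little change

The source may report more compounds than this note shows. Statements on the series, on what has been measured and on what is new or still open speak of the compounds shown alone.

In a functional assay on EC9706 cells (Homo sapiens) for cytotoxicity, read by MTT assay, with a stated time of 72 h (on this read-out higher numbers stand for weaker inhibition and lower numbers for stronger inhibition), compound 1 `O=C(CSC(=S)N[C@H]1CCOC1=O)Nc1ccc(Cl)cc1` gives > 128000 nM, which is a limit of the assay and not a number. Compound 3 `Cc1cccc(NC(=O)CSC(=S)N[C@H]2CCOC2=O)c1C` gives > 128000 nM, which is also a limit. Compound 2 `O=C(CSC(=S)N[C@H]1CCOC1=O)Nc1ccc(Br)cc1`, with bromo in place of chloro on an aromatic carbon, gives 67400 nM. For the measured compounds named here, the one measured step is an at least 1.8-fold lower number from compound 1 to compound 2 (0.27 log units; that floor lies within the scatter), and that floor stays within the usual scatter.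

Compound 4 `O=C(CSC(=S)N[C@H]1CCOC1=O)Nc1cccc(Cl)c1` has the same atoms as compound 1, joined differently: 3-chlorophenyl in place of 4-chlorophenyl on an amide-type nitrogen. In words, 3-chlorophenyl stands in place of 4-chlorophenyl on an amide-type nitrogen. Going by the values given here, no measured step shifts the chlorine, so the bromo step of compound 2 is only a loose guide, and it offers no firm ground for expecting a large change. Compound 4 may well return only a limit too, given (the limit of > 128000 nM in this assay, at which 2 of the 3 values shown sit). The expected change is an at least 1.1-fold lower number from compound 1 to compound 4 (0.06 log units; that floor lies within the scatter), which means no expected step beyond the scatter. For compound 4 the estimated value is 110000 nM, with an expected range from 50000 nM to 220000 nM.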

Compound 4, half-maximal inhibitory concentration: 107000 nM
Compound 4: the middle estimate sits 1.0-fold (0.01 log units) above what was measured; measured number inside the range.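

Moving the chlorine gives a readable number for a chlorophenyl compound in this assay, and the step is an at least 1.1-fold lower number from compound 1 to compound 4 (0.07 log units; that floor lies within the scatter). Compound 1 carries only a limit, so the true size of this shift cannot be read and only its floor is known: the limit of > 128000 nM in this assay, at which 2 of the 4 values shown sit.

The comparison between two real numbers is a 1.6-fold higher number from compound 2 to compound 4 (0.20 log units; within the scatter), so 3-chlorophenyl and 4-bromophenyl on the amide-type nitrogen cannot be told apart in this assay.

Going by these compounds, what stays open is whether an amine, a methoxy group or a carboxylic acid in place of the halogen on the phenyl ring would move the number beyond the scatter. A longer chain in place of the phenyl ring on the amide-type nitrogen is equally untested among the compounds shown.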